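The source may hold more compounds than are shown below. What is called first, only, known or untested is meant among the compounds shown, and "the series" means these compounds.

Measured compounds:
- compound 1 `Oc1cccc(-c2cc(-c3ccccc3F)cc(-c3ccccc3O)n2)c1`, in a functional assay on HeLa cells (Homo sapiens) for inhibition (on this read-out higher numbers stand for weaker inhibition and lower numbers for stronger inhibition), compound 1 gives 31100 nM
- compound 2 `Oc1ccccc1-c1cc(-c2ccccc2C(F)(F)F)cc(-c2ccccc2O)n1`, in this assay compound 2 gives 5800 nM

Compound 2 stands lowest of the two numbers in this assay; compound 1, its nearest neighbour, gives a higher number, and the gap between the two lies beyond the usual scatter. Going by the values given here, the two compounds differ in more than one place, so no single step joins them.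

Compound 3 `Oc1cccc(-c2cc(-c3ccccc3C(F)(F)F)cc(-c3ccccc3O)n2)c1` is the one not yet measured. It differs from compound 2 in one place: 3-hydroxyphenyl in place of 2-hydroxyphenyl on an aromatic carbon. Among the compounds with values here, no measured pair shows this change on its own. Compound 1, which also carries a 3-hydroxyphenyl group, gives the weaker number of the two, but it differs from compound 2 elsewhere as well. On that basis a moderate step towards weaker inhibition is expected, estimated as a 2.6-fold higher number from compound 2 to compound 3 (0.41 log units; beyond the scatter). For compound 3 the expected value in this assay is 15000 nM, within a range from 5000 nM to 45000 nM.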

Compound 3, half-maximal inhibitory concentration: 16800 nM
Compound 3: middle estimate off by 1.1-fold (0.05 log units), on the low side; measured number inside the range.
By their numbers in this assay, from the lowest: compound 2; then compounds 3 and 1 (each within the scatter of the next).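

In this assay, placing 3-hydroxyphenyl in place of 2-hydroxyphenyl on the aromatic carbon next to the ring nitrogen gives a 2.9-fold higher number from compound 2 to compound 3 (0.46 log units; beyond the scatter) and thus isolates a modest loss of inhibition for this change alone. Trifluoromethyl in place of fluoro gives a 1.9-fold lower number from compound 1 to compound 3 (0.27 log units; within the scatter) and so, with 3-hydroxyphenyl at this position, the two groups are not told apart in this read-out. No measurement on hand explains why the position of the hydroxyl group matters here.

From the compounds shown here alone, it remains open how this position would respond to a plain phenyl group, a methoxyphenyl group or an aminophenyl group, and so whether the hydroxyl group is needed at all. Going by these compounds, it is also open whether the same step between the two hydroxyphenyl groups would appear with fluoro in place of trifluoromethyl.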